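A few compounds are considered here, and "the series" means these few. Any claim that something is new, unique, unknown or untested is made for them only; others in the source may bear on it.

Measured compounds:
- compound 1 `COc1ccccc1-n1nc(C2CC(C)(C)OC(C)(C)C2)cc1-c1ccc(C)nc1`, 6 nM in an assay on HEK293 cells for inhibition of Voltage-dependent N-type calcium channel subunit alpha-1B (Homo sapiens), read by fluorescence and calcium flux, with a stated time of 5 min; a lower number here means a stronger inhibitor, a higher number a weaker inhibitor
- compound 2 `COc1ccccc1-n1nc(C2CCOC(C)(C)C2)cc1-c1ccc(Cl)cc1`, 2 nM in this assay

In this assay compound 2 gives 2 nM, the lower of the two numbers; compound 1 gives 6 nM, and the gap between them lies beyond the scatter. For the measured compounds named here, no single-point step between measured compounds is available, as compounds 1 and 2 differ in more than one place.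

Compound 3 `COc1ccccc1-n1nc([C@@H]2CCO[C@H](C(C)C)C2)cc1-c1ccc(Cl)cc1` is still to be measured in this assay. It differs from compound 2 by 2-isopropyloxan-4-yl in place of 2,2-dimethyloxan-4-yl on an aromatic carbon. The saturated ring with its oxygen is kept; the substitution on it changes and two stereocentres are now defined. Going by the values given here, with no matched step to lean on, the step from compound 2 to compound 3 is expected to be small, either direction, most likely within the scatter. Compound 3 is therefore expected near 3 nM, with a range from 1 nM to 10 nM, the expectation corresponding to a step of a 1.5-fold higher number from compound 2 to compound 3 (0.18 log units; within the scatter).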

Compound 3, half-maximal inhibitory concentration: 7 nM
Estimate against measurement, compound 3: 2.3-fold (0.37 log units) below, and the stated range covers the measured number.
By their numbers in this assay, from the lowest: compound 2; then compounds 1 and 3 (each within the scatter of the next).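

In this assay the position on the five-membered aromatic ring is sensitive to how the saturated ring is substituted: 2-isopropyloxan-4-yl in place of 2,2-dimethyloxan-4-yl gives a 3.5-fold higher number from compound 2 to compound 3 (0.54 log units; beyond the scatter) as a modest step. For the compounds shown here, the earlier compounds offered no single-place comparison, so this is the first step that can be read at this position, and it shows that the number moves even though the six-membered ring and its oxygen are kept. No measured evidence here explains the step.

The compounds shown do not separate the contribution of the isopropyl group from that of the two defined stereocentres, as both enter in the same step. Going by these compounds, how the position responds to an unsubstituted oxan-4-yl, to the other stereoisomers of compound 3, or to an amine on the saturated ring also remains open.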